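Ethoxy for oxolan-3-yl on a carbonyl carbon

This account rests on a few compounds, and the source may have more. Where it says the series, first, only, none or still open, it means among the compounds named here.

Measured in a physicochemical assay for lipophilicity, at pH 7.4; a lower number here means a more polar compound, a higher number a more lipophilic compound:
- compound 1 `CC(=O)Nc1cc(C)n(Cc2cc(Cl)ccc2OCc2ccccc2)n1`: > 3.7
- compound 2 `Cc1cc(NC(=O)C2CCOC2)nn1Cc1cc(Cl)ccc1OCc1ccccc1`: > 3.7

In this assay compound 2 gives > 3.7, which is a limit and not a number. Within the data shown here, the series so far stands at the limit of > 3.7 in this assay, at which 2 of the 2 values shown sit. The next compound is compound 3 `CCOC(=O)Nc1cc(C)n(Cc2cc(Cl)ccc2OCc2ccccc2)n1`, and the change is ethoxy in place of oxolan-3-yl on a carbonyl carbon. Among the measured compounds shown here, the one measured step that bears on it is a step that the two limits leave unreadable from compound 1 to compound 2, which also alters the group on a carbonyl carbon. That step offers no size to carry over. With no number to start from, the expected step that the limit leaves unreadable from compound 2 to compound 3 is only a rough estimate, and its direction is not firmly set. Another report of a limit is the likeliest outcome. For compound 3 the estimated value is 4, in a range from 3.6 to 4.6.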

Compound 3, distribution coefficient: > 3.7
Compound 3 ended at the assay's limit; the forecaster's own chance of this, stated with the estimate: 80%; the middle value does not contradict the limit.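

Among these compounds, compound 3 gives > 3.7 in this assay, which is a limit and not a number, so no step among compound 1, compound 2 and compound 3 can be read. The compounds shown leave open whether the group on the carbonyl carbon shifts the distribution coefficient at all: the limit of > 3.7 in this assay, at which 3 of the 3 values shown sit.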